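Working notes: from compound 2 to compound 4

The source may report more compounds than this note shows. Statements on the series, on what has been measured and on what is new or still open speak of the compounds shown alone.

In a functional assay on HL-60 cells (Homo sapiens) for inhibition, read by CCK-8 assay, with a stated time of 48 h, tested at 20 uM (a lower number here means less inhibition of growth, a higher number more inhibition of growth at the concentration tested), compound 1 (`COc1ccc(S(=O)(=O)Oc2ccccc2/C=C(\C#N)C(=O)Nc2nnc(Cc3cccc4ccccc34)s2)cc1`) gives 98%, compound 2 (`N#C/C(=C\c1ccccc1OS(=O)(=O)c1ccc([N+](=O)[O-])cc1)C(=O)Nc1nnc(Cc2cccc3ccccc23)s1`) gives 18% and compound 3 (`N#C/C(=C\c1ccccc1OS(=O)(=O)c1ccc(F)cc1)C(=O)Nc1nnc(Cc2cccc3ccccc23)s1`) gives 12% at the tested concentration. Compound 2 therefore stands far under compound 1 and cannot be told apart from compound 3.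

Compound 4 (`N#C/C(=C\c1ccccc1OS(=O)(=O)c1ccc([N+](=O)[O-])cc1)C(=O)Nc1nnc(Cc2ccc(Cl)cc2)s1`) keeps the nitro group of compound 2 and carries 4-chlorophenyl in place of naphthalen-1-yl on a saturated chain carbon bound to an aromatic carbon.

Going by the values given here, no measured step changes this group. The three available steps, a number 80 percentage points lower from compound 1 to compound 2 (beyond the scatter), a number 86 percentage points lower from compound 1 to compound 3 (beyond the scatter) and a number 6 percentage points lower from compound 2 to compound 3 (within the scatter), all concern the exchange of methoxy, nitro and fluoro on an aromatic carbon. They show that one substitution can move this series strongly, so the range stays wide, but they give no direction for the present change. Compound 2 at 18% remains the only anchor. The expected change is a number 2 percentage points higher from compound 2 to compound 4 (within the scatter), so no shift beyond the scatter is expected. Compound 4 is estimated at 20% (expected range from 6% to 50%).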

Compound 4, percent growth inhibition at one concentration: 34%
Estimate against measurement, compound 4: 14 percentage points below; the measured number falls inside the stated range.
By their numbers in this assay, from the lowest: compounds 3 and 2 (each within the scatter of the next); then compound 4; then compound 1.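

In this assay, the first step read at this position is a number 16 percentage points higher from compound 2 to compound 4 (beyond the scatter), a modest change with the nitro group held fixed. The group on the saturated chain carbon bound to an aromatic carbon therefore also moves growth inhibition in this series, which the exchanges of methoxy, nitro and fluoro on an aromatic carbon could not show. No measurement at hand explains the step.

One exchange replaces naphthalen-1-yl with 4-chlorophenyl, so the loss of one aromatic ring and the entry of chlorine cannot be separated; plain phenyl at the same place would divide the two. Also open, from the compounds shown here alone, are whether 4-chlorophenyl gives a step of similar direction with methoxy in place of nitro, and how an amine or a longer chain between the core and the ring would read.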